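This account rests on a few compounds, and the source may have more. Where it says the series, first, only, none or still open, it means among the compounds named here.

Compounds measured so far:
- compound 1, `Clc1cccc(-n2ncnc2NCc2ccccc2)c1Cl`: 209 nM
- compound 2, `Cc1ccccc1CNc1ncnn1-c1cccc(Cl)c1Cl`: 200 nM
- compound 3, `CS(=O)(=O)c1ccccc1CNc1ncnn1-c1cccc(Cl)c1Cl`: 39.8 nM

All three share one core and differ only at the saturated chain carbon bound to a nitrogen on that core. In a functional assay for antagonist activity at P2X purinoceptor 7 (Rattus norvegicus), read by FLIPR and calcium flux (on this read-out higher numbers stand for weaker inhibition and lower numbers for stronger inhibition), compound 2 stands second highest of the three numbers; its value and that of compound 1 lie within the scatter of each other, a 1.0-fold lower number from compound 1 to compound 2 (0.02 log units; within the scatter), while compound 3 sits well apart, a 5.0-fold lower number from compound 2 to compound 3 (0.70 log units; beyond the scatter).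

Compound 4, `Cc1ncccc1CNc1ncnn1-c1cccc(Cl)c1Cl`, is not yet measured. Relative to compound 2 the change is 2-methylpyridin-3-yl in place of 2-methylphenyl on a saturated chain carbon bound to a nitrogen on an aromatic ring. Going by the values given here, no measured step covers an exchange of a ring carbon for a ring nitrogen at this place; the measured steps cover only the methyl (a 1.0-fold lower number from compound 1 to compound 2 (0.02 log units; within the scatter)) and the methylsulfonyl (a 5.3-fold lower number from compound 1 to compound 3 (0.72 log units; beyond the scatter)). The methyl, kept in compound 4, produced no step beyond the scatter, and nothing here shows what the added ring nitrogen does. The expectation for compound 4 is therefore a step of a 1.3-fold lower number from compound 2 to compound 4 (0.10 log units; within the scatter) in this assay, small and not clearly beyond the scatter, with a wide range. Compound 4 is estimated at 160 nM, between 60 nM and 450 nM.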

Compound 4, half-maximal inhibitory concentration: 295 nM
Compound 4: the middle estimate sits 1.8-fold (0.27 log units) below what was measured, and the stated range covers the measured number.
By their numbers in this assay, from the lowest: compound 3; then compounds 2, 1 and 4 (each within the scatter of the next).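

In this assay, 2-methylpyridin-3-yl in place of 2-methylphenyl gives a 1.5-fold higher number from compound 2 to compound 4 (0.17 log units; within the scatter) and so shows that this exchange of a ring carbon for a ring nitrogen, with the methyl kept, produces no step beyond the scatter. The same holds against the unsubstituted phenyl, with a 1.4-fold higher number from compound 1 to compound 4 (0.15 log units; within the scatter) as the step. Among the compounds shown, the methylsulfonyl of compound 3 therefore remains the only change on this ring to give a step beyond the scatter, and no measurement at hand accounts for these results.

Still open, on these data alone, is whether a methylsulfonyl on the 2-methylpyridin-3-yl ring would give a step like that seen on the carbon-only ring. As far as these compounds go, the effects of an amine, a carboxylic acid or a longer chain on this ring also remain unknown.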